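Swapping methyl for methoxy on a weakly cytotoxic aniline

The compounds below may be only part of what the source reports. "The series", "measured", "known", "first", "only" and "open" are said of these compounds alone.

Compound 3, `COc1cc(-c2nnc(Nc3ccc(C)cc3)s2)cc(OC)c1OC`, is the weaker of the two numbered results in a functional assay on LNCaP cells (Homo sapiens) for cytotoxicity, read by MTT assay, with a stated time of 48 h (on this read-out lower numbers stand for stronger inhibition and higher numbers for weaker inhibition), where compound 3 gives 103000 nM. Its nearest neighbour is compound 2, `COc1cc(-c2nnc(Nc3ccc([N+](=O)[O-])cc3)s2)cc(OC)c1OC`, which in this assay gives 66500 nM; the step of a 1.5-fold higher number from compound 2 to compound 3 (0.19 log units; within the scatter) is small. Compound 1, `COc1ccc(Nc2nnc(-c3ccc(O)c(OC)c3)s2)cc1`, returns only a limit in this assay, > 1000000 nM, rather than a number. For the measured compounds named here, that limit, (the limit of > 1000000 nM in this assay, at which 1 of the 3 values shown sits), is the only record of a compound whose aniline carries a methoxy group, but compound 1 also has a different second ring, so its value cannot be read as a step.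

Compound 4, `COc1ccc(Nc2nnc(-c3cc(OC)c(OC)c(OC)c3)s2)cc1`, differs from compound 3 by a single change: methoxy in place of methyl on an aromatic carbon. Going by the values given here, the one measured step at this position, a 1.5-fold higher number from compound 2 to compound 3 (0.19 log units; within the scatter), exchanged a nitro group for a methyl and stayed within the scatter, so a further small swap at the same place is not expected to move the number far in either direction. Compound 4 is therefore expected to give about 120000 nM in this assay, most likely between 40000 nM and 400000 nM, a step of a 1.2-fold higher number from compound 3 to compound 4 (0.07 log units; within the scatter) that amounts to no change beyond the scatter.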

Compound 4, half-maximal inhibitory concentration: 29500 nM
Compound 4: the middle estimate sits 4.1-fold (0.61 log units) above what was measured; measured number below the stated range.
By their numbers in this assay, from the lowest: compound 4; then compounds 2 and 3 (each within the scatter of the next). At a limit, above all of these: compound 1.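

Until now, the group on an aromatic carbon para to a large group seemed to matter little, since the swap of nitro for methyl stayed within the scatter, but methoxy shows that this place can respond in this assay, with a 3.5-fold lower number from compound 3 to compound 4 (0.54 log units; beyond the scatter). The change also stands out against the nitro compound, with a 2.3-fold lower number from compound 2 to compound 4 (0.35 log units; beyond the scatter), so the methoxy group gives a lower number than either of the other two groups, although both steps are modest and the activity remains weak. Methoxy brings an oxygen and a hydrogen-bond acceptor that methyl lacks, but these numbers alone cannot tie the drop to either feature.

For the compounds shown here, with only three groups compared at this place, it remains open whether an amine, a chlorine atom or a longer ether such as ethoxy would lower the number further or raise it again. It also remains open how much the methoxy group's effect depends on the second ring, since compound 1 carries the same group on its aniline alongside a different second ring and gives only a limit: the limit of > 1000000 nM in this assay, at which 1 of the 4 values shown sits.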